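The source may report more compounds than this note shows. Statements on the series, on what has been measured and on what is new or still open speak of the compounds shown alone.

Measured so far:
compound 1 `COc1cc(-n2ncnc2-c2ccc(F)cc2)cc(OC)c1OC`: > 10000 nM
compound 2 `CCOc1ccc(-c2ncnn2-c2cc(OC)c(OC)c(OC)c2)cc1Cl`: 6 nM

Compound 1 was tested in a functional assay on HeLa cells (Homo sapiens) for antiproliferative activity, read by MTT assay, with a stated time of 72 h (a lower number here means a stronger inhibitor, a higher number a weaker inhibitor), where it gives > 10000 nM, which is a limit of the assay rather than a number. It therefore sits at the limit of > 10000 nM in this assay, at which 1 of the 2 values shown sits. Compound 2 shares the same three-methoxy-bearing ring but differs from compound 1 in several places at once, and compound 2 gives 6 nM in this assay. Within the data shown here, no single step between these two compounds is available, so their two values show only that compound 2 is the one with a numeric result.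

Compound 3 `COc1cc(-n2ncnc2-c2ccc(SC)cc2)cc(OC)c1OC` is the next compound, and it differs from compound 1 in one place: methylsulfanyl in place of fluoro on an aromatic carbon. Compound 1 offers only a limit as a starting point, so the expected step from compound 1 to compound 3 can only be a guess that it moves downward, and the estimate is an at least 5.0-fold lower number from compound 1 to compound 3 (0.69 log units; beyond the scatter). Compound 3 is therefore expected to give about 2000 nM in this assay, within a range from 150 nM to 10000 nM.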

Compound 3, half-maximal inhibitory concentration: 150 nM
Estimate against measurement, compound 3: 13-fold (1.12 log units) above, and the stated range covers the measured number.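

Replacing fluoro with methylsulfanyl on this aromatic carbon, para to a large group, gives an at least 66-fold lower number from compound 1 to compound 3 (1.82 log units; beyond the scatter) in this assay. Among these compounds, this is the first comparison here in which only one place changes, and it shows that the group at this position has a large influence on the result, since the rest of the molecule stays the same. The true size of the step remains unknown, as compound 1 gives only a limit of the assay and the step is therefore a minimum: the limit of > 10000 nM in this assay, at which 1 of the 3 values shown sits.

With only two groups to compare at this position, the compounds shown cannot tell whether the sulfur, the added methyl or the whole methylsulfanyl group matters most. On these data alone, how an amine or a nitrile would behave on this same carbon also remains open.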